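A few compounds are considered here, and "the series" means these few. Any claim that something is new, unique, unknown or untested is made for them only; others in the source may bear on it.

Of the compounds shown here, two sharing one core have been measured in a functional assay on FM3A cells (Mus musculus) for cytotoxicity, read by cell counting, with a stated time of 2 days; a higher number here means a weaker inhibitor, a lower number a stronger inhibitor. Compound 1, `CC(C)(C)c1ccc(CN2C(=O)S/C(=C\c3cccc(N)c3)C2=O)cc1`, gives 188000 nM in this assay. Compound 2, `Nc1cccc(/C=C2\SC(=O)N(Cc3cccc(F)c3)C2=O)c1`, returns only a limit of the assay, > 250000 nM in this assay, and so stands at the limit of > 250000 nM in this assay, at which 1 of the 2 values shown sits. Compound 3, `Nc1cccc(/C=C2\SC(=O)N(Cc3ccccc3)C2=O)c1`, is not yet measured; it differs from compound 2 by hydrogen in place of fluoro on an aromatic carbon. Going by the values given here, with no step between measured compounds to lean on, the step expected here, a number no higher from compound 2 to compound 3 (the limit leaves the size open), is none beyond the usual scatter. Compound 3 is accordingly estimated at 250000 nM, between 100000 nM and 600000 nM in this assay.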

Compound 3, half-maximal inhibitory concentration: > 250000 nM
Compound 3: a limit, no number; the forecaster's own chance of this, stated with the estimate: 55%; the middle value lies on the limit itself.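

In this assay compound 3, like compound 2, returns only a limit, so the step between them cannot be read and nothing can be said about what fluoro does on this ring. Replacing tert-butyl with hydrogen gives an at least 1.3-fold higher number from compound 1 to compound 3 (0.12 log units; that floor lies within the scatter), so the gap may or may not exceed the usual scatter. Only compound 1 now has a measured number: the limit of > 250000 nM in this assay, at which 2 of the 3 values shown sit.

The compounds shown leave open whether a methoxy group or a longer alkyl chain on this ring would give a number. They also leave open how an isopropyl group would compare with tert-butyl.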